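The source may hold more compounds than are shown below. What is called first, only, known or untested is meant among the compounds shown, and "the series" means these compounds.

Working notes on the series. Of the compounds shown here, two have been measured so far in a functional assay on HT-29 cells (Homo sapiens) for antiproliferative activity, read by MTT assay, with a stated time of 96 h; a higher number here means a weaker inhibitor, a lower number a stronger inhibitor. Compound 1 `O=C1CC2(CCCCC2)Oc2c1ccc1ccccc21` gives 6150 nM, and compound 2 `CSC(=S)N/N=C1\CC2(CCCCC2)Oc2c1ccc1ccccc21` gives 4130 nM. These two values lie within the scatter of each other, so compound 2 cannot be separated from compound 1 on these numbers.

The next compound to be tested is compound 3 `S=C(N/N=C1\CC2(CCCCC2)Oc2c1ccc1ccccc21)N1CCCCC1`, which is compound 2 with piperidin-1-yl in place of methylsulfanyl on a thiocarbonyl carbon. For the measured compounds named here, no measured pair covers this exchange, so the data offer no direct precedent for its size or direction. Going by the values given here, the only guide is the narrow spread of the two values in hand, with compound 1 at 6150 nM and compound 2 at 4130 nM. On that thin basis, no step beyond the scatter is expected in this assay, and no direction is favoured with any confidence. The estimated change is a 1.2-fold lower number from compound 2 to compound 3 (0.07 log units; within the scatter). For compound 3 the expected value is 3500 nM, with an estimated range from 1000 nM to 12000 nM.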

Compound 3, half-maximal inhibitory concentration: 6770 nM
Compound 3: the middle estimate sits 1.9-fold (0.29 log units) below what was measured, and the stated range covers the measured number.
By their numbers in this assay, from the lowest: compounds 2, 1 and 3 (each within the scatter of the next).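

The exchange of methylsulfanyl for piperidin-1-yl on a thiocarbonyl carbon gives the series its first step at this position: in this assay the change is a 1.6-fold higher number from compound 2 to compound 3 (0.21 log units; within the scatter) and lies within the scatter. The entering group has 6 heavy atoms against 2 for the group that leaves, and it brings a six-membered non-aromatic ring, yet the step cannot be told from the scatter of repeated measurements, so this one exchange shows this position accepting a much larger group with no resolved change in this assay. Nothing measured bears on why the step has this size.

Whether any group at this position can move the number beyond the scatter remains open, since only methylsulfanyl and piperidin-1-yl are shown on this carbon, and a small open-chain amine such as dimethylamino, a morpholin-4-yl ring or a chain ending in a carboxylic acid would test this further. For the compounds shown here, also open is whether the same exchange would give a similar step on a core other than the one shared by compound 2 and compound 3.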